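Little Movement Expected From a Fluorinated Phenyl Exchange

The source may report more compounds than this note shows. Statements on the series, on what has been measured and on what is new or still open speak of the compounds shown alone.

In a functional assay on HT-29 cells (Homo sapiens) (on this read-out higher numbers stand for weaker inhibition of growth and lower numbers for stronger inhibition of growth), compound 1 `O=S(=O)(/C=C/c1ccc(Cl)cc1)Cc1ccc(Nc2ncnc3ccccc23)cc1` gives 73000 nM and compound 2 `O=S(=O)(/C=C/c1ccc(F)cc1Cl)Cc1ccc(Nc2ncnc3ccccc23)cc1` gives 100000 nM as its value, which stands level with compound 1 within the scatter. The change 2-fluoro-4-(trifluoromethyl)phenyl in place of 2-chloro-4-fluorophenyl on a double-bonded chain carbon bound to a double-bonded chain carbon leads to compound 3 `O=S(=O)(/C=C/c1ccc(C(F)(F)F)cc1F)Cc1ccc(Nc2ncnc3ccccc23)cc1` by placing 2-fluoro-4-(trifluoromethyl)phenyl on a double-bonded chain carbon bound to a double-bonded chain carbon. Among the measured compounds shown here, the only measured step at this place is a 1.4-fold higher number from compound 1 to compound 2 (0.14 log units; within the scatter) and it lies within the scatter, so no step beyond the scatter is expected in this assay for this exchange. The expected step is a 1.3-fold lower number from compound 2 to compound 3 (0.10 log units; within the scatter) and it stays within the scatter. Compound 3 is estimated at 80000 nM with an expected range from 35000 nM to 180000 nM on this read-out.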

Compound 3, concentration for 50% growth inhibition: 100000 nM
Compound 3: the middle estimate sits 1.3-fold (0.10 log units) below what was measured; measured number inside the range.
By their numbers in this assay, from the lowest: compounds 1, 2 and 3 (each within the scatter of the next).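

Replacing 2-chloro-4-fluorophenyl by 2-fluoro-4-(trifluoromethyl)phenyl gives in this assay no change at the digits printed from compound 2 to compound 3 (within the scatter) and, measured against the 4-chlorophenyl compound, a 1.4-fold higher number from compound 1 to compound 3 (0.14 log units; within the scatter). All three phenyl groups on a double-bonded chain carbon thus stand level within the scatter, now including one that carries trifluoromethyl. No available evidence explains this flat result.

On these data alone, whether an amine or a carboxylic acid at this place would produce a step beyond the scatter remains open. So does the effect of any change elsewhere on the shared core.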